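The compounds below may be only part of what the source reports. "The series", "measured", "known", "first", "only" and "open" are said of these compounds alone.

Working notes on the series. Three compounds share one core; compound 1 `Cc1ccc(/C=C2\CCC/C(=C\c3cccc([N+](=O)[O-])c3)C2=O)cc1`, compound 2 `CN(C)c1ccc(/C=C2\CCC/C(=C\c3ccccc3[N+](=O)[O-])C2=O)cc1` and compound 3 `O=C1/C(=C/c2ccc(F)cc2)CCC/C1=C\c1cccc([N+](=O)[O-])c1` have been measured in a functional assay on MOLT-4 cells (Homo sapiens) for cytotoxicity, with a stated time of 72 h; a lower number here means a stronger inhibitor, a higher number a weaker inhibitor. Compound 1 gives 9530 nM, compound 2 gives 122000 nM, and compound 3 gives 5120 nM. Compound 3 thus has the lowest number of the three, though its gap to compound 1 lies within the scatter; only compound 2 stands clearly apart. Among the measured compounds shown here, the one single-point step among them, a 1.9-fold lower number from compound 1 to compound 3 (0.27 log units; within the scatter), is small.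

Compound 4 `CN(C)c1ccc(/C=C2\CCC/C(=C\c3cccc([N+](=O)[O-])c3)C2=O)cc1` is not yet measured. Its change from compound 3 is dimethylamino in place of fluoro on an aromatic carbon. For the measured compounds named here, no measured step reports this exact change, so the one step known, from compound 1 to compound 3, bears on it only in showing that a small swap at this carbon did little. Dimethylamino also appears in compound 2, which differs from compound 4 elsewhere as well; compound 2 gives 122000 nM, a high number. On that basis compound 4 is expected to show a 3.9-fold higher number from compound 3 to compound 4 (0.59 log units; beyond the scatter), an estimate of uncertain size. The estimate for compound 4 in this assay is 20000 nM, with a range from 6000 nM to 70000 nM.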

Compound 4, half-maximal inhibitory concentration: 10900 nM
Compound 4: the middle estimate sits 1.8-fold (0.26 log units) above what was measured, within the range that was stated.
By their numbers in this assay, from the lowest: compounds 3, 1 and 4 (each within the scatter of the next, the first and the last beyond it); then compound 2.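

In this assay, among the compounds shown here, the aromatic carbon para to a large group now holds a third group, and the larger dimethylamino gives only a modest shift against fluoro, a 2.1-fold higher number from compound 3 to compound 4 (0.33 log units; beyond the scatter), while against methyl it gives a 1.1-fold higher number from compound 1 to compound 4 (0.06 log units; within the scatter), so only the first of these two swaps at this carbon registers at all. The new compound also separates the dimethylamino group from the high number of compound 2: with dimethylamino held fixed, 3-nitrophenyl in place of 2-nitrophenyl gives an 11-fold lower number from compound 2 to compound 4 (1.05 log units; beyond the scatter). Among the compounds shown, the change in the nitrophenyl group therefore outweighs every change at the para carbon, and the high number of compound 2 goes with 2-nitrophenyl rather than with dimethylamino.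

No data at hand give a reason for either the modest step or the large one. The compounds shown leave open whether a primary amine or a carboxylic acid at the para carbon would stay this close to fluoro and methyl, and whether the large nitrophenyl step recurs with fluoro or methyl in place of dimethylamino.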